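Compound 4: hydrogen in place of trifluoromethyl

A few compounds are considered here, and "the series" means these few. Any claim that something is new, unique, unknown or untested is made for them only; others in the source may bear on it.

In a functional assay on T47D cells (Homo sapiens) for inhibition, read by CCK-8 assay, with a stated time of 72 h, tested at 1 uM (a higher number here means more inhibition of growth at the concentration tested, a lower number less inhibition of growth), three compounds built on one shared core have been measured. Compound 1 `CN(C)C(=O)c1cc2cnc(Nc3ccc(NC(=O)C4(C(=O)Nc5cccc(F)c5)CC4)cc3)nc2n1C1CCCC1` gives -3.2%, compound 2 `CN(C)C(=O)c1cc2cnc(Nc3ccc(NC(=O)C4(C(=O)Nc5cccc(Br)c5)CC4)cc3)nc2n1C1CCCC1` gives 29.1%, and compound 3 `CN(C)C(=O)c1cc2cnc(Nc3ccc(NC(=O)C4(C(=O)Nc5ccc(C(F)(F)F)cc5)CC4)cc3)nc2n1C1CCCC1` gives 29.6%. Compound 3 stands level with compound 2, with a number 0.5 percentage points higher from compound 2 to compound 3 (within the scatter), and well clear of compound 1, with a number 32.8 percentage points higher from compound 1 to compound 3 (beyond the scatter).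

Compound 4 `CN(C)C(=O)c1cc2cnc(Nc3ccc(NC(=O)C4(C(=O)Nc5ccccc5)CC4)cc3)nc2n1C1CCCC1` has hydrogen in place of trifluoromethyl on an aromatic carbon, para to a large group: hydrogen in place of trifluoromethyl on an aromatic carbon. For the measured compounds named here, no measured step makes this exact swap, and no measured compound lacks a substituent on that ring. The nearest guides are the two large steps up from compound 1, namely a number 32.8 percentage points higher from compound 1 to compound 3 (beyond the scatter) and a number 32.3 percentage points higher from compound 1 to compound 2 (beyond the scatter). Both show that a small fluoro compound can sit far lower than compound 3, so a moderate fall is expected, with wide uncertainty. The expected change is a number 17.6 percentage points lower from compound 3 to compound 4 (beyond the scatter). For compound 4 the estimated value is 12%, with an expected range from -6% to 32%.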

Compound 4, percent growth inhibition at one concentration: 52.8%
Estimate against measurement, compound 4: 40.8 percentage points below; measured number outside the range, above it.
By their numbers in this assay, from the lowest: compound 1; then compounds 2 and 3 (each within the scatter of the next); then compound 4.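

With no substituent on this aromatic carbon, the ring gives the highest number in the series in this assay, with a number 23.2 percentage points higher from compound 3 to compound 4 (beyond the scatter) and a number 23.7 percentage points higher from compound 2 to compound 4 (beyond the scatter) in the same direction. The earlier compounds shown here compared only substituted rings, where fluoro sat far below bromo and trifluoromethyl; the further step, with a number 56 percentage points higher from compound 1 to compound 4 (beyond the scatter) as its measure, now shows that all three of these groups lie below hydrogen, fluoro by the widest margin. Nothing available explains why hydrogen does better here.

On these data alone, whether a methoxy group, an amine or a carboxylic acid on this ring would also fall below hydrogen remains open. So does whether the order of these four compounds would hold at other concentrations or in other cell lines.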